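The source may hold more compounds than are shown below. What is called first, only, known or untested is meant among the compounds shown, and "the series" means these compounds.

Measured so far:
compound 1 `ClCc1ccccc1Cn1cnc2ncnc(Cl)c21` — 26900 nM
compound 2 `ClCc1ccc(Cn2cnc3c(Cl)nc(Cl)nc32)cc1` — 66100 nM

In a functional assay on OVCAR-5 cells (Homo sapiens) for cytotoxicity, read by sulforhodamine B assay, with a stated time of 48 h (a lower number here means that less compound is tolerated, a higher number that more compound is tolerated), compound 1 gives the lowest of the two numbers; compound 2 shows a higher number, beyond the scatter, but the two structures differ in more than one place, so no single step can be read from them. Compound 3 `ClCc1ccccc1Cn1cnc2nc(Cl)nc(Cl)c21` has not been measured. It differs from compound 1 by chloro in place of hydrogen on an aromatic carbon. Among the compounds with values here, with no measured step for this change, only a small shift is expected, if any, from compound 1 to compound 3 in this assay, estimated as a 1.3-fold higher number from compound 1 to compound 3 (0.11 log units; within the scatter). Compound 3 is therefore expected to give about 35000 nM, within 15000 nM to 80000 nM.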

Compound 3, concentration lethal to 50% of the cells: 28800 nM
Compound 3: the middle estimate sits 1.2-fold (0.08 log units) above what was measured, and the stated range covers the measured number.
By their numbers in this assay, from the lowest: compounds 1 and 3 (each within the scatter of the next); then compound 2.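

Read in this assay the chloro in place of hydrogen on this aromatic carbon, between two ring nitrogen atoms, gives a 1.1-fold higher number from compound 1 to compound 3 (0.03 log units; within the scatter) and so stays within the scatter. Within the data shown here, this is the first single-place step in the set, and it shows that this carbon carries a chloro group without a readable change in the number. Nothing available explains this result. On these data alone, whether an amine or a longer chain on the same carbon would leave the number equally in place stays open, as do the other positions of the shared core.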